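Mirror image of compound 3: what to expect

The source may hold more compounds than are shown below. What is called first, only, known or untested is meant among the compounds shown, and "the series" means these compounds.

Measured compounds:
compound 1, `Cn1ccnc1C(CC(=O)O)c1ccc(OCC2COc3ccc(Cl)cc3O2)cc1`, 5880 nM
compound 2, `O=C(O)CC1(c2ccc(OCC3COc4ccc(Cl)cc4O3)cc2)COC1`, 8060 nM
compound 3, `CC#C[C@@H](CC(=O)O)c1ccc(OC[C@H]2COc3ccc(Cl)cc3O2)cc1`, 50 nM

All three were run in a functional assay on HEK293 cells for agonist activity at Free fatty acid receptor 1 (Homo sapiens), read by fluorescence and calcium flux, with a stated time of 10 min; a higher number here means that more compound is needed for the effect, a lower number that less compound is needed. Compound 3 stands lowest of the three numbers, and both gaps to it are beyond the scatter: compound 1 gives 5880 nM and compound 2 gives 8060 nM, whereas compound 3 gives 50 nM. So compound 3 is the most potent of the measured set. Within the data shown here, no single-point steps between measured compounds are available, so the numbers for compounds 1 and 2 can only be read as what they are.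

Compound 4, `CC#C[C@H](CC(=O)O)c1ccc(OC[C@@H]2COc3ccc(Cl)cc3O2)cc1`, is the next compound for this assay. How it differs from compound 3: the two compounds have the same atoms and bonds and differ only in configuration as drawn: 2 of 2 stereo elements differ (all stereocentres are inverted: mirror images); a stereocentre at a saturated chain carbon is drawn S in compound 3 and R in compound 4; a stereocentre at a saturated ring carbon is drawn S in compound 3 and R in compound 4. Nothing leaves and nothing enters; the change is purely one of configuration at both stereocentres. Among the measured compounds shown here, with no measured enantiomer pair in this set, the size of the step cannot be anchored to data of its own. For the measured compounds named here, the expectation is that the mirror image will need more compound than compound 3, a step beyond the scatter and likely large, since compound 3 is the one well-separated low value here. The expected step is a 30-fold higher number from compound 3 to compound 4 (1.48 log units; beyond the scatter). Compound 4 is estimated to give 1500 nM, within a range from 250 nM to 9000 nM.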

Compound 4, half-maximal effective concentration: 5040 nM
Beside the measured number, compound 4's estimate is 3.4-fold (0.53 log units) below it, and the stated range covers the measured number.
By their numbers in this assay, from the lowest: compound 3; then compounds 4, 1 and 2 (each within the scatter of the next).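

In this assay, among these compounds, inverting both stereocentres gives a 100-fold higher number from compound 3 to compound 4 (2.00 log units; beyond the scatter), the first single-change step. The whole of this large step belongs to configuration, because no atom or bond changes, as shown by this: the fact that compounds 3 and 4 differ only in the configuration as drawn. Among the compounds shown here, the earlier values offered no such pair, so this is the first direct sign that the series is sensitive to configuration, with the arrangement drawn S at both the saturated chain carbon and the saturated ring carbon giving the lower number of the two mirror images.

Going by these compounds, both stereocentres invert together here, so the share of the step carried by the saturated chain carbon and by the saturated ring carbon stays open. Also open, on these data alone, is whether the same sensitivity holds with a nitrile or a cyclopropyl group at the saturated chain carbon.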